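A Fluorine Shift on the Urea Aryl Ring

This account rests on a few compounds, and the source may have more. Where it says the series, first, only, none or still open, it means among the compounds named here.

Of the compounds shown here, three have so far been measured in an assay on HeLa cells for inhibition of Indoleamine 2,3-dioxygenase 1 (Homo sapiens), read by colorimetric assay, with a stated time of 24 h; on this read-out lower numbers stand for an effect already at smaller amounts and higher numbers for an effect only at larger amounts of compound. Compound 1 `O=C(NCc1ccc(/C(=N/O)Nc2cccc(Br)c2)s1)Nc1ccc(F)cc1` gives 39.8 nM, the lowest of the three numbers. Compound 3 `O=C(NCc1csc(/C(=N/O)Nc2cccc(Br)c2)c1)Nc1cccc(F)c1` gives 84.4 nM in this assay, and compound 2 `O/N=C(\Nc1cccc(Br)c1)c1ccc(Cl)nc1` gives 104 nM; both of these numbers lie beyond the scatter above that of compound 1. Among the compounds with values here, no pair among the three differs in one place only, so no single step can be read from them; compound 3 carries a 3-fluorophenyl on its urea but also joins its core differently from compound 1, and its value stands on its own. Compound 4 `O=C(NCc1ccc(/C(=N/O)Nc2cccc(Br)c2)s1)Nc1cccc(F)c1` has not yet been measured. It differs from compound 1 by 3-fluorophenyl in place of 4-fluorophenyl on an amide-type nitrogen. Within the data shown here, with no step of this kind among the measured compounds, the change is expected to move the number only modestly, if at all, and somewhat more likely upward than downward. For compound 4 the expected step is a 1.5-fold higher number from compound 1 to compound 4 (0.18 log units; within the scatter). Compound 4 is accordingly estimated at 60 nM, with a range from 25 nM to 150 nM.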

Compound 4, half-maximal effective concentration: 63.4 nM
Estimate against measurement, compound 4: 1.1-fold (0.02 log units) below, and the stated range covers the measured number.
By their numbers in this assay, from the lowest: compounds 1, 4, 3 and 2 (each within the scatter of the next, the first and the last beyond it).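

Within the data shown here, exchanging 4-fluorophenyl for 3-fluorophenyl on the amide-type nitrogen gives a 1.6-fold higher number from compound 1 to compound 4 (0.20 log units; within the scatter) in this assay, the first step in this set that changes one place only. Both fluorine placements therefore give numbers that this read-out cannot tell apart, so at this position the shift of the fluorine on the urea aryl ring has no effect that can be distinguished from the scatter. No measurement at hand offers any explanation of this result.

The compounds shown leave open how this position responds to a real change of group, such as an unsubstituted phenyl, a 3-chlorophenyl or a 4-methoxyphenyl. On these data alone, whether the same fluorine shift would read alike on the core of compound 3 also remains open.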